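Phenol ester series: methoxy in place of methyl

This account rests on a few compounds, and the source may have more. Where it says the series, first, only, none or still open, it means among the compounds named here.

Measured compounds:
compound 1 `CC(C)(C)c1cc(OC(=O)c2ccc(Cl)cc2)ccc1O` in an assay on isolated protein for antagonist activity at Bile acid receptor (Homo sapiens), read by HTRF, with a stated time of 30 min (a higher number here means a weaker inhibitor, a lower number a stronger inhibitor), gives > 100000 nM, a limit of the assay.
compound 2 `CC(C)(C)c1cc(OC(=O)c2ccccc2)ccc1O` gives > 100000 nM, a limit.
compound 3 `Cc1ccccc1C(=O)Oc1ccc(O)c(C(C)(C)C)c1` gives > 100000 nM, a limit.

Compound 3 thus stands at the assay limit, as do the other two members; no number separates them, and the limit of > 100000 nM in this assay, at which 3 of the 3 values shown sit, is where every value sits. For the measured compounds named here, the steps that bear on the series, a step that the two limits leave unreadable from compound 1 to compound 2, a step that the two limits leave unreadable from compound 1 to compound 3 and a step that the two limits leave unreadable from compound 2 to compound 3, are all unreadable, since each joins two limits.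

Compound 4 `COc1ccccc1C(=O)Oc1ccc(O)c(C(C)(C)C)c1` is the unmeasured member. Its change from compound 3 is methoxy in place of methyl on an aromatic carbon, placed on an aromatic carbon of a six-membered aromatic ring of carbon only, ortho to a large group. Going by the values given here, no measured step shows what this change does; the measured steps give only limits at both ends. With every neighbour at the limit, compound 4 is expected to remain at or near the limit. The step from compound 3 to compound 4 is therefore expected to be a number no higher from compound 3 to compound 4 (the limit leaves the size open). Compound 4 is estimated at 100000 nM, within 30000 nM to 300000 nM.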

Compound 4, half-maximal inhibitory concentration: > 100000 nM
Compound 4 gave a limit, no number; the forecaster's own chance of this, stated with the estimate: 85%; the middle value sits exactly at the limit.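

In this assay, for the compounds shown here, compound 4 gives > 100000 nM, a limit, so no step from compound 3 or compound 2 to compound 4 can be read. The compounds shown leave open whether any change on the shared core gives a measurable value: the limit of > 100000 nM in this assay, at which 4 of the 4 values shown sit.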